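A few compounds are considered here, and "the series" means these few. Any claim that something is new, unique, unknown or untested is made for them only; others in the source may bear on it.

Compound 2 `COc1cccc(/C=C/C(=O)c2sc(Nc3ccccc3)nc2C)c1` in a functional assay on BGC-823 cells (Homo sapiens) for cytotoxicity, read by MTT assay (on this read-out higher numbers stand for weaker inhibition and lower numbers for stronger inhibition), gives 14300 nM. Compound 1 `COc1cccc(/C=C/C(=O)c2sc(Nc3cccc(C)c3)nc2C)c1` differs from it by methyl in place of hydrogen on an aromatic carbon. In this assay compound 1 gives only a limit, > 25000 nM. The step of an at least 1.7-fold higher number from compound 2 to compound 1 (0.24 log units; that floor lies within the scatter) is therefore a floor rather than a measured size. Compound 3 `COc1cc(/C=C/C(=O)c2sc(Nc3ccccc3)nc2C)cc(OC)c1OC` has a core whose difference from compound 2 is not broken down here. In this assay compound 3 also gives only a limit, > 25000 nM. Compound 4 `COc1cc(/C=C/C(=O)c2sc(Nc3ccc(C)cc3)nc2C)cc(OC)c1OC` differs from compound 3 by methyl in place of hydrogen on an aromatic carbon; this is the same kind of change as from compound 2 to compound 1, but the place differs, para to a large group here against meta there. Because the limit of > 25000 nM in this assay, at which 2 of the 3 values shown sit, already holds compound 3, the expected step that the limit leaves unreadable from compound 3 to compound 4 is small. Compound 4 is estimated at 30000 nM.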

Compound 4, half-maximal inhibitory concentration: > 25000 nM
Compound 4: only a limit was reported; the forecaster's own chance of this, stated with the estimate: 80%; the middle value does not contradict the limit.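

Among these compounds, compound 3 and compound 4 both give only a limit in this assay, so no step between them can be read: the limit of > 25000 nM in this assay, at which 3 of the 4 values shown sit. The compounds shown leave open how far past that limit either compound lies, and so what the methyl changes here.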